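The source may hold more compounds than are shown below. What is called first, only, known or untested is meant among the compounds shown, and "the series" means these compounds.

Measured in a physicochemical assay for lipophilicity, at pH 7.4; a higher number here means a more lipophilic compound, a lower number a more polar compound:

- compound 1 `Cc1ccc2nc(NC(=O)c3ccc(C(C)(C)C)cc3)sc2c1`: 5.08
- compound 2 `CC(C)(C)c1ccc(C(=O)Nc2cn3cc(-c4ccccc4)ccc3n2)cc1`: 4.83

Compound 2, at 4.83, lies within the usual scatter of compound 1, at 5.08, so these two values cannot be told apart. Among the compounds with values here, both compounds carry the same tert-butyl-substituted benzamide, but their cores differ, and no measured pair differs in one place only. Within the data shown here, the data therefore hold no direct precedent for the next change.

Compound 3 `CNCc1ccc2nc(NC(=O)c3ccc(C(C)(C)C)cc3)cn2c1` differs from compound 2 in a single place: (methylamino)methyl in place of phenyl on an aromatic carbon. The group that leaves is an aromatic ring of carbon only, while the group that enters has no ring and contains nitrogen. This estimate therefore rests on the structural change alone, starting from compound 2 at 4.83. A large downward move in this assay is expected, well beyond the scatter. The expected step, a number 2.43 log units lower from compound 2 to compound 3 (beyond the scatter), is correspondingly large. For compound 3 the estimated value is 2.4, with an expected range from 1.7 to 3.2.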

Compound 3, distribution coefficient: 2.4
Estimate against measurement, compound 3: no gap at the digits printed; measured number inside the range.
By their numbers in this assay, from the lowest: compound 3; then compounds 2 and 1 (each within the scatter of the next).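

In this assay, putting (methylamino)methyl in place of phenyl gives a number 2.43 log units lower from compound 2 to compound 3 (beyond the scatter), the first single-place comparison among these compounds, and it shows that the read-out responds strongly to what sits on this aromatic carbon of the six-membered aromatic ring with 1 nitrogen. Compounds 1 and 2 could not show this: their cores differ and their values lie within the scatter of each other, whereas here the tert-butyl-substituted benzamide and the core stay the same, so the whole step belongs to this one place. The change does, however, remove an aromatic ring of carbon only and bring in a chain with nitrogen in a single move, and nothing available explains the size of the step.

On these data alone, whether the step follows from the loss of the ring or from the entry of the nitrogen stays open, and a plain propyl chain or a pyridyl ring at this place would separate the two. Also open, as far as these compounds go, is whether a primary amine or a carboxylic acid here would give a step of similar size, and whether the same change would do so on the core of compound 1.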